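From benzyl to 2-hydroxy-5-nitrophenyl on the amide nitrogen

The compounds below may be only part of what the source reports. "The series", "measured", "known", "first", "only" and "open" are said of these compounds alone.

Compound 1 `COc1ccc(C(=O)/C=C/c2ccc(C(=O)NCc3ccccc3)cc2)c(O)c1`: > 100000 nM, a limit
Compound 2 `CCCCCCCCCCCCNC(=O)c1ccc(/C=C/C(=O)c2ccc(OC)cc2O)cc1`: > 100000 nM, a limit

Both compounds were tested in an ADME assay on SH-SY5Y cells (Homo sapiens) for cytotoxicity, read by MTT assay, with a stated time of 48 h; on this read-out higher numbers stand for weaker inhibition and lower numbers for stronger inhibition. Compound 1 stands at > 100000 nM, which is a limit and not a number. For the measured compounds named here, the only measured step is a step that the two limits leave unreadable from compound 1 to compound 2, with undecyl in place of phenyl on a saturated chain carbon bound to an amide-type nitrogen. All the evidence so far is the limit of > 100000 nM in this assay, at which 2 of the 2 values shown sit.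

Compound 3 `COc1ccc(C(=O)/C=C/c2ccc(C(=O)Nc3cc([N+](=O)[O-])ccc3O)cc2)c(O)c1` has not yet been measured. It differs from compound 1 by 2-hydroxy-5-nitrophenyl in place of benzyl on an amide-type nitrogen. The measured step gives no size to carry over to this change. Compound 1 gives only its limit of > 100000 nM, so any readable change in this assay could only run toward stronger inhibition. The expected step is an at least 1.2-fold lower number from compound 1 to compound 3 (0.09 log units; that floor lies within the scatter), and compound 3 may well report a limit too. For compound 3 the estimate is 80000 nM, with an expected range of 25000 nM to 100000 nM.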

Compound 3, half-maximal inhibitory concentration: > 100000 nM
Compound 3 ended at the assay's limit; the forecaster's own chance of this, stated with the estimate: 55%; middle value at least 1.2-fold (0.09 log units) away from the limit.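

For the compounds shown here, compound 3, like compound 1, ended at a limit of this assay, so no step between compound 1 and compound 3 can be read. The compounds shown leave open whether any group on the amide-type nitrogen would give a readable value in this assay.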